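The source may hold more compounds than are shown below. What is called first, only, known or untested is meant among the compounds shown, and "the series" means these compounds.

Series notes, step from compound 3 to compound 4.

Compound 1 `CCOC(=O)CCCCCOc1cccc(CN(C(=O)c2ccc(-c3ccc4[nH]ccc4c3)cc2)C(C)C)c1`, compound 2 `CCOC(=O)CCCCCOc1cccc(CN(C(=O)c2ccc(-c3ccc4cc[nH]c4c3)cc2)C(C)C)c1` and compound 3 `CCOC(=O)CCCCCOc1cccc(CN(C(=O)c2ccc(-c3cc(OC)cc(OC)c3)cc2)C(C)C)c1` share one core and differ only in the group on the aromatic carbon para to the large group. In an ADME assay on HEK293 cells (Homo sapiens) for cytotoxicity, read by CellTiter-Glo and resazurin assay, with a stated time of 72 h (on this read-out lower numbers stand for an effect already at smaller amounts and higher numbers for an effect only at larger amounts of compound), compound 1 gives only a limit, > 26000 nM. Compound 2 likewise gives only a limit in this assay, > 26000 nM. Compound 3 stands at a limit as well in this assay, > 26000 nM. So no number is known for any of the three; all sit at the limit of > 26000 nM in this assay, at which 3 of the 3 values shown sit. The three steps between them are therefore not readable: a step that the two limits leave unreadable from compound 1 to compound 2, a step that the two limits leave unreadable from compound 1 to compound 3 and a step that the two limits leave unreadable from compound 2 to compound 3.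

Compound 4 `CCOC(=O)CCCCCOc1cccc(CN(C(=O)c2ccc(-c3cccc(CC(=O)O)c3)cc2)C(C)C)c1` is not yet measured in this assay. It differs from compound 3 as follows: 3-(carboxymethyl)phenyl in place of 3,5-dimethoxyphenyl on an aromatic carbon. Among the compounds with values here, none of the measured steps carries a readable size, so no direction can be drawn from them; the only bearing is that three different groups at this position all left the read-out at the limit. For compound 4 the expectation is therefore a step no larger than the scatter, a step that the limit leaves unreadable from compound 3 to compound 4, with a high chance that only a limit is again reported. The estimate for compound 4 in this assay is 40000 nM, ranging from 20000 nM to 120000 nM.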

Compound 4, half-maximal effective concentration: > 26000 nM
Compound 4: no number, only a limit; the forecaster's own chance of this, stated with the estimate: 85%; the middle value lies beyond the limit too.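

In this assay compound 4 gives only a limit, > 26000 nM. No new step can be read, since the steps linking compound 4 to compound 1, compound 2 and compound 3 all end at a limit: the limit of > 26000 nM in this assay, at which 4 of the 4 values shown sit.

The compounds shown leave open whether the group on this aromatic carbon changes the read-out at all, and at what concentration any of the four would show an effect.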